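A Small Change Measured Once, Expected Again

The source may report more compounds than this note shows. Statements on the series, on what has been measured and on what is new or still open speak of the compounds shown alone.

Measured so far:
compound 1 `CCSc1ccc(C2C(Oc3ccccc3)C(=O)N2c2cc(OC)c(OC)c(OC)c2)cc1`: 632 nM
compound 2 `COc1cc(N2C(=O)C(Oc3ccccc3)C2c2ccc(SC)cc2)cc(OC)c1OC`: 336 nM
compound 3 `COc1cc(N2C(=O)C(C3CC3)C2c2ccc(SC)cc2)cc(OC)c1OC`: 204 nM

In a functional assay on HT-29 cells (Homo sapiens) for inhibition, read by sulforhodamine B assay, with a stated time of 72 h (on this read-out lower numbers stand for stronger inhibition and higher numbers for weaker inhibition), compound 2 gives 336 nM, while compound 1 gives 632 nM. The change between these two is methyl in place of hydrogen on a saturated chain carbon bound to a sulfur, and it made the step of a 1.9-fold higher number from compound 2 to compound 1 (0.27 log units; within the scatter). Compound 3 differs from compound 2 in the core itself, by cyclopropyl in place of phenoxy on a saturated ring carbon. In this assay compound 3 gives 204 nM, a step of a 1.6-fold lower number from compound 2 to compound 3 (0.22 log units; within the scatter).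

Compound 4 `CCSc1ccc(C2C(C3CC3)C(=O)N2c2cc(OC)c(OC)c(OC)c2)cc1` has not been measured. It differs from compound 3 by methyl in place of hydrogen on a saturated chain carbon bound to a sulfur. Going by the values given here, this is the same change, at the same place, as the one from compound 2 to compound 1; only the core it sits on is different. The expectation for compound 4 therefore rests on that single earlier step: because a 1.9-fold higher number from compound 2 to compound 1 (0.27 log units; within the scatter) stayed within the scatter, the step to compound 4 is expected to be of similar size, about a 1.9-fold higher number from compound 3 to compound 4 (0.28 log units; within the scatter). Compound 4 is thus estimated at 390 nM in this assay, with a likely range from 200 nM to 800 nM.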

Compound 4, half-maximal inhibitory concentration: 1560 nM
Compound 4: middle estimate off by 4.0-fold (0.60 log units), on the low side; measured number above the stated range.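

With cyclopropyl on the core, the change from 4-(methylsulfanyl)phenyl to 4-(ethylsulfanyl)phenyl gave a 7.6-fold higher number from compound 3 to compound 4 (0.88 log units; beyond the scatter) in this assay, and it did not keep the size it had with phenoxy on the core: the same change on two cores in this assay, a 1.9-fold higher number (0.27 log units; within the scatter) from compound 2 to compound 1 and a 7.6-fold higher number (0.88 log units; beyond the scatter) from compound 3 to compound 4, 4.1-fold (0.61 log units) apart, beyond the scatter of two such steps. Read the other way, putting cyclopropyl in place of phenoxy on the ethylsulfanyl pair gave a 2.5-fold higher number from compound 1 to compound 4 (0.39 log units; beyond the scatter), and this does not match the same swap on the methylsulfanyl pair: the same change on two cores in this assay, a 1.6-fold lower number (0.22 log units; within the scatter) from compound 2 to compound 3 and a 2.5-fold higher number (0.39 log units; beyond the scatter) from compound 1 to compound 4, 4.1-fold (0.61 log units) apart, beyond the scatter of two such steps. Among these four compounds, then, the two changes do not act independently, so a step measured on one core was a poor guide on the other, but this says nothing about why the steps differ or how they would behave on any further core.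

The compounds shown leave open how a longer chain on the sulfur, such as propyl, would behave on either core. They also leave open whether a different group in place of phenoxy or cyclopropyl, such as an amine, would show the same dependence on the ethylsulfanyl group.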